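Swapping the aryl group on a fused triazolothiadiazine core

This account rests on a few compounds, and the source may have more. Where it says the series, first, only, none or still open, it means among the compounds named here.

Measured so far:
- compound 1, `Cc1ccc(C2=Nn3c(Cc4ccc(S(C)(=O)=O)cc4)nnc3SC2)cc1`: "not active" (no number reported)
- compound 2, `CS(=O)(=O)c1ccc(Cc2nnc3n2N=C(c2cc4ccccc4c(=O)o2)CS3)cc1`: 22.4%

Both compounds were tested in a functional assay on RAW264.7 cells (Mus musculus) for cytotoxicity, read by MTT assay, with a stated time of 48 h, tested at 12.5 uM; a higher number here means a stronger effect of the compound at the concentration tested, a lower number a weaker effect. Compound 1 was reported in this assay as "not active" (no number reported), so no number stands for it, and its place on the scale cannot be given more closely than that. Compound 2 carries a different ring in the same position and in this assay gives 22.4%, a modest read-out at the tested concentration. Without a number for compound 1, no size can be stated for the gap between the two.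

The unmeasured compound 3, `CS(=O)(=O)c1ccc(Cc2nnc3n2N=C(c2cc(Cl)sc2Cl)CS3)cc1`, differs from compound 1 in one place: 2,5-dichlorothiophen-3-yl in place of 4-methylphenyl on a carbon with a double bond to nitrogen. For the measured compounds named here, no measured pair shows what such a change does here, so the expectation rests only on the two results at hand. Since compound 1 showed no activity and compound 2, with another ring in the same place, reached only a small read-out, the step in this assay is expected to be small, if any, and may well stay within the scatter. Compound 3 is therefore estimated to give 12%, with a range from 0% to 30%.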

Compound 3, a percentage reported as activity, at one concentration (the size of the read-out at that concentration, not a potency): "not active" (no number reported)
No number was reported for compound 3; there is nothing to compare the estimate with.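

Compound 1 and compound 3 both lack a number in this assay, so no step can be read between them. Nothing shown here bears on the reason for this result. The compounds shown leave open whether 2,5-dichlorothiophen-3-yl in place of 4-methylphenyl changes the read-out at all.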